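Tetrazole in Place of Nitrile on a Dithiocarbamate Chain

This account rests on a few compounds, and the source may have more. Where it says the series, first, only, none or still open, it means among the compounds named here.

Compound 1 `N#CCCSC(=S)NCc1cccnc1`: 1030 nM
Compound 2 `Cc1nc(-c2ccccc2)oc1CNC(=S)SCCC#N`: 18000 nM
Compound 3 `N#CCCSC(=S)NCc1nnc(-c2ccccc2)s1`: 18700 nM

Among the three compounds measured in a functional assay on Bel-7402 cells (Homo sapiens) for cytotoxicity, read by resazurin assay, with a stated time of 72 h (a higher number here means a weaker inhibitor, a lower number a stronger inhibitor), compound 1 gives the lowest number, and its gaps to compound 2 and compound 3 both lie beyond the usual scatter, so compound 1 is the strongest inhibitor here. Compound 4 `S=C(NCc1cccnc1)SCCc1nnn[nH]1` keeps the core of compound 1 and differs in one place: 1H-tetrazol-5-yl in place of cyano on a saturated chain carbon, two bonds along the chain from a sulfur. Among the measured compounds shown here, no pair of measured compounds shows this change, so its effect in this assay is unknown. The step from a small nitrile to a five-membered aromatic ring is expected to weaken inhibition somewhat, shown as a 2.9-fold higher number from compound 1 to compound 4 (0.46 log units; beyond the scatter). Compound 4 is therefore estimated at 3000 nM, with a range from 800 nM to 12000 nM.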

Compound 4, half-maximal inhibitory concentration: 57700 nM
Compound 4: the middle estimate sits 19-fold (1.28 log units) below what was measured; the whole stated range lies below it.
By their numbers in this assay, from the lowest: compound 1; then compounds 2 and 3 (each within the scatter of the next); then compound 4.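

The chain end of the molecule turns out to be highly sensitive to change: with the core of compound 1 unchanged, replacing cyano with 1H-tetrazol-5-yl gives a 56-fold higher number from compound 1 to compound 4 (1.75 log units; beyond the scatter). This single replacement therefore has a large effect on the measured number. Nothing shown here explains that loss.

As far as these compounds go, whether the loss is specific to the tetrazole or extends to other replacements at this place remains open. A carboxylic acid, a primary amide or a longer chain ending in the nitrile could help to separate these possibilities.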